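Swapping Chloro for Methoxy and Watching Cell Toxicity

The source may report more compounds than this note shows. Statements on the series, on what has been measured and on what is new or still open speak of the compounds shown alone.

Of the compounds shown here, three that share one core have been measured in an ADME assay on HEL cells (Homo sapiens) for cytotoxicity; on this read-out higher numbers stand for lower toxicity in this test and lower numbers for higher toxicity in this test. Compound 1 `O=C(COc1cccc2ccccc12)N/N=C/c1ccc(Cl)cc1` holds the highest of the two plain numbers: in this assay compound 1 gives 100 ug/mL. Its nearest neighbour is compound 3 `C/C(=N\NC(=O)COc1cccc2ccccc12)c1ccccc1O`, and in this assay compound 3 gives 20 ug/mL, a gap that lies beyond the usual scatter of this kind of test. Compound 2 `COc1cc(/C=N/NC(=O)COc2cccc3ccccc23)cc(OC)c1OC` is reported only as a limit of the assay: in this assay compound 2 gives >= 20 ug/mL, a boundary rather than a number (the limit of >= 20 ug/mL in this assay, at which 1 of the 3 values shown sits).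

Not yet measured is compound 4 `COc1ccc(/C=N/NC(=O)COc2cccc3ccccc23)cc1`, which differs from compound 1 in a single place (methoxy in place of chloro on an aromatic carbon). The change, then, is a methoxy group taking the spot of a chloro group.

Within the data shown here, no measured pair shows this exact swap, so the size of the step from compound 1 to compound 4 in this assay must be guessed. The two plain numbers in hand, from compound 1 and compound 3, span a range beyond the scatter, and nothing points upward from compound 1. A downward step of modest size is therefore expected, a 2.0-fold lower number from compound 1 to compound 4 (0.30 log units; within the scatter), with a real chance that the result lands within the scatter of compound 1. Compound 4 is thus estimated at 50 ug/mL, expected to fall between 20 ug/mL and 100 ug/mL.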

Compound 4, minimum cytotoxic concentration: 20 ug/mL
For compound 4 the middle estimate is 2.5-fold (0.40 log units) above the measured one, and the stated range covers the measured number.
By their numbers in this assay, from the lowest: compounds 3 and 4 (each within the scatter of the next); then compound 1.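

In this assay, among these compounds, the swap from 4-chlorophenyl to 4-methoxyphenyl gives the first step that can be read at a single place, on an aromatic carbon para to a large group: a 5.0-fold lower number from compound 1 to compound 4 (0.70 log units; beyond the scatter). This shows that the position is not silent, since exchanging just this one group on the shared core moves the read-out beyond the usual scatter, in the direction of higher toxicity in this test. Compound 2, which also carries methoxy groups but differs from compound 1 in more than one place, stands only as a limit and adds no number to set beside this step: the limit of >= 20 ug/mL in this assay, at which 1 of the 4 values shown sits.

The compounds shown leave open whether this drop is special to methoxy or would follow from removing chloro in general, a question that a plain hydrogen, a fluoro, a methyl or an amine at the same place could begin to answer. They also leave open whether the same swap would give a step of similar size on a different core, as this single pair cannot establish a general rule.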